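Amide series: acyl versus benzyl on the amine nitrogen

The source may hold more compounds than are shown below. What is called first, only, known or untested is meant among the compounds shown, and "the series" means these compounds.

Measured so far:
compound 1 `CC(C(=O)Nc1cc(F)cc(F)c1)N(C(=O)c1ccc(Cl)cc1)C1CCCCC1`, 3980 nM
compound 2 `O=C(CN(Cc1ccc(Cl)cc1)C1CCCCC1)Nc1cc(F)cc(F)c1`, a limit only, > 25100 nM

In an assay on HEK293 cells for inhibition of sodium- and chloride-dependent glycine transporter 1 (Homo sapiens), read by scintillation proximity assay (on this read-out higher numbers stand for weaker inhibition and lower numbers for stronger inhibition), compound 1 gives 3980 nM. For compound 2 the read-out in this assay is only a limit, > 25100 nM, so compound 2 sits at the weak end of the numbers shown (the limit of > 25100 nM in this assay, at which 1 of the 2 values shown sits). Compound 3 `O=C(CN(C(=O)C1CCOCC1)C1CCCCC1)Nc1cc(F)cc(F)c1` differs from compound 2 by (oxan-4-yl)carbonyl in place of 4-chlorobenzyl on an amine nitrogen. Compound 1 carries an acyl group on that nitrogen and gives 3980 nM. Within the data shown here, no measured step joins compound 2 to a neighbour. The step expected in this assay is an at least 1.6-fold lower number from compound 2 to compound 3 (0.22 log units; that floor lies within the scatter), towards stronger inhibition. Compound 3 is expected near 15000 nM, within 4000 nM to 50000 nM.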

Compound 3, half-maximal inhibitory concentration: 5010 nM
For compound 3 the middle estimate is 3.0-fold (0.48 log units) above the measured one; measured number inside the range.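

On the amine nitrogen whose other neighbours are a saturated chain carbon and a saturated ring carbon, (oxan-4-yl)carbonyl in place of 4-chlorobenzyl gives an at least 5.0-fold lower number from compound 2 to compound 3 (0.69 log units; beyond the scatter) in this assay. Among these compounds, this is the only readable step at this position, and it lies beyond the scatter. Compound 2 is held only as a limit, so the step is a floor: the limit of > 25100 nM in this assay, at which 1 of the 3 values shown sits.

As far as these compounds go, whether the step follows the carbonyl or the oxan-4-yl ring stays open. An oxan-4-ylmethyl group on the same nitrogen would separate the two.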